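This account rests on a few compounds, and the source may have more. Where it says the series, first, only, none or still open, it means among the compounds named here.

Measured compounds:
Compound 1, `COc1ccc(-c2nc(N=C(N)N)sc2-c2ccc(OC)cc2)cc1`, giving 2 uM in a functional assay (aorta) with Rattus norvegicus as the target; a lower number here means that less compound is needed, a higher number that more compound is needed for the effect.
Compound 2, `CNC(=N)Nc1nc(-c2ccc(OC)cc2)c(-c2ccc(OC)cc2)s1`, giving 1.2 uM in this assay.
Compound 3, `COc1ccc(-c2nc(CNC(=O)N3CCOCC3)sc2-c2ccc(OC)cc2)cc1`, giving 12 uM in this assay.

Compound 1 stands second highest of the three numbers. Its nearest neighbour is compound 2, reached by a 1.7-fold lower number from compound 1 to compound 2 (0.22 log units; within the scatter), a step that stays within the scatter. Its furthest is compound 3, reached by a 6.0-fold higher number from compound 1 to compound 3 (0.78 log units; beyond the scatter), which lies beyond it.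

Compound 4, `COc1ccc(-c2nc(C(=O)N3CCOCC3)sc2-c2ccc(OC)cc2)cc1`, has not yet been measured in this assay. It differs from compound 1 in one place: a group of 8 heavy atoms (5 carbon, 1 nitrogen, 2 oxygen; one six-membered non-aromatic ring with 2 hetero atoms) in place of a group of 4 heavy atoms (1 carbon, 3 nitrogen; no ring), on an aromatic carbon.

Among the compounds with values here, two measured steps bear on this change, since both put a morpholine-containing group in place of a small nitrogen-rich group on the same aromatic carbon: a 6.0-fold higher number from compound 1 to compound 3 (0.78 log units; beyond the scatter) and a 10-fold higher number from compound 2 to compound 3 (1.00 log units; beyond the scatter). Within the data shown here, both run in the same direction and both exceed the scatter, though the group entering compound 4 is smaller than the one in compound 3. Compound 4 is therefore expected to show a higher number than compound 1, by about a 5.0-fold higher number from compound 1 to compound 4 (0.70 log units; beyond the scatter), a modest step in the same sense. On that basis compound 4 is estimated at 10 uM, with a likely range from 3 uM to 35 uM.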

Compound 4, concentration for half-maximal effect: < 100 uM
Compound 4: no number, only a limit; the forecaster's own chance of this, stated with the estimate: 10%; the middle value does not contradict the limit.
By their numbers in this assay, from the lowest: compounds 2 and 1 (each within the scatter of the next); then compound 3.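

In this assay compound 4 gives < 100 uM, which is a limit of the assay and not a number, so its steps from compound 1, compound 2 and compound 3 cannot be read. The compounds shown leave open where compound 4, with its (morpholin-4-yl)carbonyl group, stands relative to those three.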